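The compounds below may be only part of what the source reports. "The series", "measured", "known", "first", "only" and "open" are said of these compounds alone.

Measured compounds:
- compound 1, `COc1cccc(CC[C@](N)(C(=O)O)C2C[C@@H]2C(=O)O)c1`: 430 nM
- compound 2, `NC(CCc1cccc(C(=O)O)c1)(C(=O)O)[C@H]1C[C@@H]1C(=O)O`: 1800 nM

Both have been run in a functional assay on RGT cells for inhibition of metabotropic glutamate receptor 2 (Homo sapiens); on this read-out lower numbers stand for stronger inhibition and higher numbers for weaker inhibition. Compound 1 gives 430 nM, the lowest of the two numbers; compound 2 gives 1800 nM, a higher number that lies beyond the scatter of this assay. The two differ in more than one place, so no single exchange among the measured compounds can be read as a step, and no scale for an isolated change is available from the series itself.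

Compound 3, `Nc1cccc(CC[C@](N)(C(=O)O)C2C[C@@H]2C(=O)O)c1`, has not yet been measured. It is derived from compound 1 by the change (amino in place of methoxy on an aromatic carbon), that is, amino in place of methoxy on an aromatic carbon. Going by the values given here, with no measured step to lean on, the expectation for compound 3 is worded cautiously: the step from compound 1 is expected to be small, most likely towards a somewhat higher number, and it may not exceed the scatter; the expected step is a 1.6-fold higher number from compound 1 to compound 3 (0.21 log units; within the scatter). In this assay compound 3 is estimated at 700 nM, with a range from 200 nM to 2500 nM.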

Compound 3, half-maximal inhibitory concentration: 3100 nM
For compound 3 the middle estimate is 4.4-fold (0.65 log units) below the measured one; the whole stated range lies below it.
By their numbers in this assay, from the lowest: compound 1; then compounds 2 and 3 (each within the scatter of the next).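

In this assay, going by these compounds alone, the exchange of methoxy for amino on an aromatic carbon gives a 7.2-fold higher number from compound 1 to compound 3 (0.86 log units; beyond the scatter) and is the first step that can be read at a single place. The position, on an aromatic carbon of a six-membered aromatic ring of carbon only and meta to a large group, is therefore not indifferent to the group it carries, and this exchange is not tolerated without loss on this read-out. The leaving methoxy counts 2 heavy atoms and 0 hydrogen-bond donors, the entering amino 1 heavy atom and 1 hydrogen-bond donor, but no measurement shown here ties the step to either difference.

One exchange cannot separate the count of heavy atoms from the count of hydrogen-bond donors, and a methyl, a hydroxyl or an ethoxy at the same place would bear on that question. Also open, on these data alone, is whether methoxy itself is favourable here or amino is unfavourable, which a comparison with hydrogen at this carbon would help to settle.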